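This account rests on a few compounds, and the source may have more. Where it says the series, first, only, none or still open, it means among the compounds named here.

Measured compounds:
- compound 1, `Cc1ccc(-n2nnc(C(=O)Nc3ccc(SC#N)cc3)c2C)cc1C`: 61000 nM
- compound 2, `Cc1ccc(Cl)c(-n2nnc(C(=O)Nc3ccc(SC#N)cc3)c2C)c1`: 68000 nM

Both measured compounds were tested in a functional assay on KB 3-1 cells (Homo sapiens) for antiproliferative activity, read by MTT assay, with a stated time of 72 h; a lower number here means a stronger inhibitor of growth, a higher number a weaker inhibitor of growth. In this assay compound 1 gives 61000 nM and compound 2 gives 68000 nM. Among the measured compounds shown here, compound 1 has the lowest of the two numbers, but the only step available, a 1.1-fold higher number from compound 1 to compound 2 (0.05 log units; within the scatter), lies within the scatter, so the two compounds cannot be told apart on these numbers.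

Compound 3, `COc1cccc(-n2nnc(C(=O)Nc3ccc(SC#N)cc3)c2C)c1`, has not yet been measured. It differs from compound 1 in one place: 3-methoxyphenyl in place of 3,4-dimethylphenyl on an aromatic nitrogen.

For the measured compounds named here, no measured step matches this change. Going by the values given here, the single step on record, from compound 1 to compound 2, swaps one substituted phenyl for another on the same aromatic nitrogen and moves the number by a 1.1-fold higher number from compound 1 to compound 2 (0.05 log units; within the scatter). Among the compounds with values here, that is the only guide here: one exchange of the aryl group at this position left the number where it was. On that basis no step beyond the scatter is expected for compound 3, and an expected step of a 1.1-fold higher number from compound 1 to compound 3 (0.03 log units; within the scatter) is assumed. Compound 3 is therefore estimated at 65000 nM, with a range from 25000 nM to 170000 nM.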

Compound 3, concentration for 50% growth inhibition: > 100000 nM
Compound 3: only a limit was reported (the forecaster's own chance of this, stated with the estimate: 15%); middle value at least 1.5-fold (0.18 log units) from the limit.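

In this assay compound 3 gives > 100000 nM, and this is a limit, not a number. Set against the two earlier aryl groups, it gives an at least 1.6-fold higher number from compound 1 to compound 3 (0.21 log units; that floor lies within the scatter) and an at least 1.4-fold higher number from compound 2 to compound 3 (0.16 log units; that floor lies within the scatter), and since both floors lie within the scatter, compound 3 cannot yet be separated from either neighbour. What the result adds is that a third aryl group on this aromatic nitrogen, and the first of the three to carry an oxygen, shows no sign of a lower number than compound 1 or compound 2, while the true size of the step stays unknown because the reading ends at a limit: the limit of > 100000 nM in this assay, at which 1 of the 3 values shown sits.

All the compounds shown share the same core and differ only in this aryl group, and with no step beyond the scatter it stays open whether this position matters much for growth inhibition at all. Also open, going by these compounds, is what an amine or a carboxylic acid on this phenyl ring would do to the number, or a longer chain such as ethoxy in place of the methoxy group.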